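Swapping Cyclopropyl for Thiophen-2-yl on a Shared Core

A few compounds are considered here, and "the series" means these few. Any claim that something is new, unique, unknown or untested is made for them only; others in the source may bear on it.

Compound 3 `CC(C)n1ncc2c(C(=O)Nc3ccccn3)cc(C3CC3)nc21` was tested in an ADME assay on LLC-MK2 cells (Macaca mulatta) for cytotoxicity, read by spectrophotometry and crystal violet staining, with a stated time of 4 days (a lower number here means that less compound is tolerated, a higher number that more compound is tolerated), where compound 3 gives 25000 nM. That is level with compound 1 `CC(C)n1ncc2c(C(=O)Nc3cc(S(N)(=O)=O)ccc3F)cc(-c3cccs3)nc21`, which in this assay gives 25000 nM, and the two share the lowest numbers of the three; compound 2 `CC(C)n1ncc2c(C(=O)Nc3cccc(F)c3F)cc(-c3cccs3)nc21` gives 75000 nM, a higher number that lies beyond the scatter. Compound 4 `CC(C)n1ncc2c(C(=O)Nc3ccccn3)cc(-c3cccs3)nc21` differs from compound 3 in one place: thiophen-2-yl in place of cyclopropyl on an aromatic carbon. Compound 1 already carries thiophen-2-yl and gives 25000 nM, level with compound 3, so for compound 4 only a small step is expected, a 1.2-fold higher number from compound 3 to compound 4 (0.08 log units; within the scatter), in no firm direction. Compound 4 is therefore estimated at 30000 nM, with a range from 12000 nM to 75000 nM.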

Compound 4, half-maximal cytotoxic concentration: > 200000 nM
Compound 4 was reported as a limit; the forecaster's own chance of this, stated with the estimate: 15%; middle value at least 6.6-fold (0.82 log units) from the limit.
By their numbers in this assay, from the lowest: compounds 1 and 3 (each within the scatter of the next); then compound 2. At a limit, above all of these: compound 4.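

With pyridin-2-yl kept on the amide-type nitrogen, thiophen-2-yl in place of cyclopropyl gives an at least 8.0-fold higher number from compound 3 to compound 4 (0.90 log units; beyond the scatter) in this assay and so shows that the group at this position can shift the number clearly. With thiophen-2-yl kept, pyridin-2-yl in place of 2,3-difluorophenyl gives an at least 2.6-fold higher number from compound 2 to compound 4 (0.42 log units; beyond the scatter) and shows that thiophen-2-yl alone does not set the number. Compound 4 is reported only as a limit, so both steps are minimum sizes: the limit of > 200000 nM in this assay, at which 1 of the 4 values shown sits.

Going by these compounds, how far compound 4 truly lies from the others stays open. So does what an amine or a plain phenyl at this position would give.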